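Swapping piperidin-1-yl for morpholin-4-yl on the amide carbonyl

The compounds below may be only part of what the source reports. "The series", "measured", "known", "first", "only" and "open" are said of these compounds alone.

Measured in a functional assay on a cell-free system (Platelet, plasma, Homo sapiens) for inhibition, read by turbidimetry, with a stated time of 3 min; on this read-out higher numbers stand for weaker inhibition and lower numbers for stronger inhibition:
- Compound 1 `COc1ccc(-n2nc(C(=O)N3CCOCC3)cc2-c2ccc(Cl)cc2)nn1`: 83 nM
- Compound 2 `CS(=O)(=O)c1ccc(-n2nc(C(=O)N3CCOCC3)cc2-c2ccc(Cl)cc2)nn1`: > 20000 nM (a limit of the assay)
- Compound 3 `COc1ccc(-n2nc(C(=O)N3CCCCC3)cc2-c2ccc(Cl)cc2)cc1`: 7.9 nM

Among the two true numbers, compound 3 holds the lower one, so it is the stronger inhibitor of that pair, and compound 1 is its nearest neighbour. Compound 4 `COc1ccc(-n2nc(C(=O)N3CCOCC3)cc2-c2ccc(Cl)cc2)cc1` is compound 3 with a single change: morpholin-4-yl in place of piperidin-1-yl on a carbonyl carbon.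

Within the data shown here, the only measured step, an at least 240-fold higher number from compound 1 to compound 2 (2.38 log units; beyond the scatter), is large, but it swaps methoxy for methylsulfonyl on an aromatic carbon and leaves the carbonyl group untouched. It therefore gives no direct guide here. The closest hint is that the (morpholin-4-yl)carbonyl of compound 4 also occurs in compound 1, at 83 nM, although the rest of the core differs there. A modest move towards weaker inhibition seems likely, held with little certainty. The estimated change is a 3.2-fold higher number from compound 3 to compound 4 (0.50 log units; beyond the scatter). For compound 4 the expected value is 25 nM, with an estimated range of 6 nM to 100 nM.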

Compound 4, half-maximal inhibitory concentration: 7.3 nM
Compound 4: the middle estimate sits 3.4-fold (0.53 log units) above what was measured, within the range that was stated.
By their numbers in this assay, from the lowest: compounds 4 and 3 (each within the scatter of the next); then compound 1. At a limit, above all of these: compound 2.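

In this assay, the change on the carbonyl carbon gives a 1.1-fold lower number from compound 3 to compound 4 (0.03 log units; within the scatter), so this pair does not separate morpholin-4-yl from piperidin-1-yl, although morpholin-4-yl carries one hydrogen-bond acceptor and piperidin-1-yl none. With morpholin-4-yl held in place, 4-methoxyphenyl in place of 6-methoxypyridazin-3-yl on the aromatic nitrogen gives an 11-fold lower number from compound 1 to compound 4 (1.06 log units; beyond the scatter), so the higher number of compound 1 goes with that group and not with its morpholin-4-yl. The step with 4-methoxyphenyl in place of 6-(methylsulfonyl)pyridazin-3-yl, an at least 2700-fold lower number from compound 2 to compound 4 (3.43 log units; beyond the scatter), starts from a limit and so gives only a minimum size: the limit of > 20000 nM in this assay, at which 1 of the 4 values shown sits.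

As far as these compounds go, it remains open whether a piperazin-1-yl ring, with its second ring nitrogen, or an open-chain diethylamino group on the carbonyl carbon would read like these two rings. From the compounds shown here alone, it is also open whether piperidin-1-yl and morpholin-4-yl would still match with 6-methoxypyridazin-3-yl on the aromatic nitrogen.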